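Replacing a Chloropyridinylmethyl Group with a Fluorobenzyl Group

The compounds below may be only part of what the source reports. "The series", "measured", "known", "first", "only" and "open" are said of these compounds alone.

Compound 1 `Cc1ccc2c(NCc3ccc(NC(=O)C4CCN(Cc5cc(Cl)ccn5)CC4)cc3)nc(N(C)C)nc2c1` was tested in a functional assay on SV5A8 cells (Homo sapiens) for cytotoxicity; on this read-out higher numbers stand for weaker inhibition and lower numbers for stronger inhibition. In this assay compound 1 gives > 5400 nM, which is a limit of the assay rather than a number. Compound 1 therefore stands only at a limit, namely (the limit of > 5400 nM in this assay, at which 1 of the 2 values shown sits). Compound 2 `Cc1ccc2c(NCc3ccc(NC(=O)C4CCN(Cc5ccccc5)CC4)cc3)nc(N3CCN[C@@H](C)C3)nc2c1` shows the same kind of result. In this assay compound 2 gives > 8860 nM, again a limit of the assay. Both values shown are limits. No order between compound 1 and compound 2 can be drawn from them. Compound 3 `Cc1ccc2c(NCc3ccc(NC(=O)C4CCN(Cc5ccccc5F)CC4)cc3)nc(N(C)C)nc2c1` differs from compound 1 on a saturated chain carbon bound to an amine nitrogen in a ring: 2-fluorophenyl in place of 4-chloropyridin-2-yl on a saturated chain carbon bound to an amine nitrogen in a ring. Going by the values given here, no measured pair differs in one place alone, so no step size is known from the data. Compound 3 is expected to give 8000 nM, with a range from 3000 nM to 25000 nM, in this assay. That estimate means a step that the limit leaves unreadable from compound 1 to compound 3 expected to be none beyond the scatter, with a limit rather than a number the likely outcome.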

Compound 3, half-maximal inhibitory concentration: > 6670 nM
Compound 3 ended at the assay's limit; the forecaster's own chance of this, stated with the estimate: 75%; the middle value lies beyond the limit too.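

In this assay, going by these compounds alone, compound 1 and compound 3 both stand at limits of the assay, so no step between them can be read. The compounds shown leave open whether 2-fluorophenyl in place of 4-chloropyridin-2-yl changes the read-out at all, and what number any compound would give.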